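A Heteroaryl Swap on the Ring Amine Nitrogen

The source may report more compounds than this note shows. Statements on the series, on what has been measured and on what is new or still open speak of the compounds shown alone.

For the measured compounds named here, compound 2 `CCCS(=O)(=O)N1CC=C(c2ccc3c(c2)CC(C2CCN(c4ncc(C(F)(F)F)cn4)CC2)O3)CC1` stands highest of the two numbers so far in a functional assay on HEK293 cells with Glucose-dependent insulinotropic receptor (Homo sapiens) as the target, read by cAMP accumulation, with a stated time of 60 min; a lower number here means a smaller maximal response, a higher number a larger maximal response: compound 2 reaches 118%, whereas compound 1 `CCCS(=O)(=O)N1CC=C(c2ccc3c(c2)CC(C2CCN(S(=O)(=O)CCC)CC2)O3)CC1` reaches 43%. Going by the values given here, the one measured step, a number 75 percentage points higher from compound 1 to compound 2 (beyond the scatter), concerns a different exchange. Compound 3 `CCCS(=O)(=O)N1CC=C(c2ccc3c(c2)CC(C2CCN(c4ccc(C(F)(F)F)cn4)CC2)O3)CC1` differs from compound 2 in one place: 5-(trifluoromethyl)pyridin-2-yl in place of 5-(trifluoromethyl)pyrimidin-2-yl on an amine nitrogen in a ring. Among the compounds with values here, no measured step bears on this exchange, so the account rests on the neighbouring value alone and expects from compound 2 to compound 3 a step of a number 8 percentage points lower from compound 2 to compound 3 (within the scatter), within the scatter. Compound 3 is therefore estimated at 110%, with a range from 85% to 130% in this assay.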

Compound 3, largest response reached (Emax), in percent of the reference or control that the assay uses: 99%
Compound 3: the middle estimate sits 11 percentage points above what was measured, within the range that was stated.
By their numbers in this assay, from the lowest: compound 1; then compound 3; then compound 2.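

In this assay, the amine nitrogen in a ring responds even to a small change within the heteroaryl group: 5-(trifluoromethyl)pyridin-2-yl, with one ring hetero atom, in place of 5-(trifluoromethyl)pyrimidin-2-yl, with two, gives a number 19 percentage points lower from compound 2 to compound 3 (beyond the scatter) in maximal response. The gain over propylsulfonyl is not confined to the pyrimidine, as the pyridine also gives a number 56 percentage points higher from compound 1 to compound 3 (beyond the scatter) at this position. No data here explain why the two heteroaryl groups differ. The compounds shown leave open how a plain phenyl ring would fare on this nitrogen, and whether a nitrile could replace the trifluoromethyl.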